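Removing a hydroxy group from a weak inhibitor

The source may hold more compounds than are shown below. What is called first, only, known or untested is meant among the compounds shown, and "the series" means these compounds.

Measured in a functional assay on DLD-1 cells (Homo sapiens) for inhibition, with a stated time of 48 h; a higher number here means a weaker inhibitor, a lower number a stronger inhibitor:
Compound 1 `COc1cc2oc(/C=C/[S+](C)[O-])cc(=O)c2cc1O`: > 10000 nM (a limit)
Compound 2 `C[S+]([O-])/C=C/c1cc(=O)c2ccccc2o1`: 1000 nM

Compound 1 gives no exact number, only a limit, and so it sits at the limit of > 10000 nM in this assay, at which 1 of the 2 values shown sits. Going by these compounds, how much weaker or stronger its true value might be is unknown. For the measured compounds named here, compound 2 is the only compound here with a measured number, 1000 nM.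

Compound 3 `COc1ccc2c(=O)cc(/C=C/[S+](C)[O-])oc2c1` has not yet been measured. It differs from compound 1 in a single place: hydrogen in place of hydroxy on an aromatic carbon. In words, this is hydrogen in place of hydroxy on an aromatic carbon, ortho to a methoxy group. Going by the values given here, no measured pair shows what such a swap does, so any prediction is uncertain.

Compound 2, at 1000 nM, shows that a compound in this small set can reach a measurable value in this assay. A change towards stronger inhibition, beyond the usual scatter, is therefore expected, although compound 3 could also end up at the limit. The expected change is an at least 4.0-fold lower number from compound 1 to compound 3 (0.60 log units; beyond the scatter). Compound 3 is estimated at 2500 nM, with an expected range from 600 nM to 10000 nM.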

Compound 3, half-maximal inhibitory concentration: 1800 nM
Beside the measured number, compound 3's estimate is 1.4-fold (0.14 log units) above it; the range from low to high includes it.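

In this assay, replacing the hydroxy group ortho to a methoxy group with hydrogen gives an at least 5.5-fold lower number from compound 1 to compound 3 (0.74 log units; beyond the scatter), so this aromatic carbon matters for the read-out when the methoxy group is present. The other new step, methoxy in place of hydrogen on an aromatic carbon, gives a 1.8-fold higher number from compound 2 to compound 3 (0.26 log units; within the scatter), so in these two compounds, which carry no hydroxy group, adding the methoxy group produces no change beyond the usual scatter. The first step gives only a minimum, and its true size remains unknown, because compound 1 has a limit rather than an exact value: the limit of > 10000 nM in this assay, at which 1 of the 3 values shown sits.

The compounds shown carry only hydroxy or hydrogen at this carbon, so it remains open how a fluorine atom, an amine or a carboxylic acid there would behave in this assay. It is also unclear whether the hydroxy group would have the same effect without the methoxy group, a question that only a compound carrying the hydroxy group alone on the shared core could answer.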